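The source may report more compounds than this note shows. Statements on the series, on what has been measured and on what is new or still open speak of the compounds shown alone.

Two compounds of the series have been run in a functional assay on the whole organism (strain Wistar albino) for inhibition, with Rattus norvegicus as the target, read by paw edema, with stated times of 1 h and 2 h, at a dose of 0.32 mmol/kg by the intraperitoneal route; on this read-out lower numbers stand for less inhibition and higher numbers for more inhibition at the one dose given (going by the name of the read-out). Compound 1 `Cc1ccc(-c2nn(-c3ccc(Cl)cc3)cc2/C=C\C(=O)c2ccc(Cl)cc2)cc1` gives 49.2%. Compound 2 `Cc1ccc(-c2nn(-c3ccc(Cl)cc3)cc2C(CC(=O)c2ccc(Cl)cc2)C(=O)c2ccc(F)cc2)cc1` gives 25.9%, the lower of the two numbers, and the gap to compound 1 lies beyond the scatter; the two differ in more than one place, so the numbers alone are noted. Compound 3 `COc1ccc(C(=O)C(CC(=O)c2ccc(Cl)cc2)c2cn(-c3ccc(Cl)cc3)nc2-c2ccc(C)cc2)cc1` is not yet measured. It differs from compound 2 by methoxy in place of fluoro on an aromatic carbon. Nothing measured bears on this change, so a step of a number 2.1 percentage points higher from compound 2 to compound 3 (within the scatter) is expected, which is none beyond the scatter. Compound 3 is therefore estimated at 28%, in the range 15% to 42%.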

Compound 3, a percentage reported as inhibition, in the whole organism at one dose (the size of the read-out at that dose, not a potency): 16.1%
Beside the measured number, compound 3's estimate is 11.9 percentage points above it; low and high end bracket the measured number.
By their numbers in this assay, from the lowest: compounds 3 and 2 (each within the scatter of the next); then compound 1.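

Going by these compounds alone, the first one-place pair in this assay gives a number 9.8 percentage points lower from compound 2 to compound 3 (within the scatter) for methoxy in place of fluoro on an aromatic carbon para to a large group. This change adds an oxygen hydrogen-bond acceptor and one heavy atom at this position, yet the step stays within the scatter, so the read-out does not separate these two groups. No measured property of these compounds bears on this step.

Open, going by these compounds, is how an amine, a carboxylic acid or a longer alkoxy chain on this carbon would read. Also open, on these data alone, is whether the same change behaves alike at other positions of the series.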